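One Aryl Swap on a Sulfonyl Sulfur: What to Expect

A few compounds are considered here, and "the series" means these few. Any claim that something is new, unique, unknown or untested is made for them only; others in the source may bear on it.

Measured in a functional assay on 143B cells (Homo sapiens) for antiproliferative activity, read by MTT assay, with a stated time of 48 h; on this read-out higher numbers stand for weaker inhibition and lower numbers for stronger inhibition:
Compound 1 `Cc1ccc(C(=O)Nc2cccc(/C=C/C(=O)c3nc4ccccc4[nH]3)c2)cc1` gives 6560 nM.
Compound 2 `COc1cccc(C(=O)Nc2cccc(/C=C/C(=O)c3nc4ccccc4[nH]3)c2)c1` gives 4610 nM.
Compound 3 `O=C(/C=C/c1cccc(NS(=O)(=O)c2ccccc2Cl)c1)c1nc2ccccc2[nH]1` gives 4790 nM.

Compound 3 sits second highest of these three numbers, yet its gaps to the others, a 1.0-fold higher number from compound 2 to compound 3 (0.02 log units; within the scatter) and a 1.4-fold lower number from compound 1 to compound 3 (0.14 log units; within the scatter), are both within the scatter, so the three compounds read alike in this assay.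

Compound 4 `Cc1ccc(S(=O)(=O)Nc2cccc(/C=C/C(=O)c3nc4ccccc4[nH]3)c2)cc1` differs from compound 3 by 4-methylphenyl in place of 2-chlorophenyl on a sulfonyl sulfur. Among the compounds with values here, no measured step changes only the ring on the sulfonyl sulfur; the closest are a 1.4-fold lower number from compound 1 to compound 3 (0.14 log units; within the scatter), which introduced the (2-chlorophenyl)sulfonyl group, and a 1.4-fold lower number from compound 1 to compound 2 (0.15 log units; within the scatter), which changed the ring on a carbonyl carbon, both within the scatter. The step is therefore expected to be small, a 1.0-fold higher number from compound 3 to compound 4 (0.02 log units; within the scatter), in no clear direction. Compound 4 is estimated at 5000 nM, between 2500 nM and 10000 nM.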

Compound 4, half-maximal inhibitory concentration: 3220 nM
Estimate against measurement, compound 4: 1.6-fold (0.19 log units) above; measured number inside the range.
By their numbers in this assay, from the lowest: compounds 4, 2, 3 and 1 (each within the scatter of the next, the first and the last beyond it).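

The first direct read of the ring on the sulfonyl sulfur in this assay is small (a 1.5-fold lower number from compound 3 to compound 4 (0.17 log units; within the scatter)), so 2-chlorophenyl and 4-methylphenyl read alike at this position. Within the data shown here, the (4-methylphenyl)sulfonyl group also reads alike with the (3-methoxyphenyl)carbonyl group (a 1.4-fold lower number from compound 2 to compound 4 (0.16 log units; within the scatter)), but with the 4-methylphenyl ring kept, sulfonyl in place of carbonyl gives the first step beyond the scatter, a modest one (a 2.0-fold lower number from compound 1 to compound 4 (0.31 log units; beyond the scatter)). No measurement here explains that step. As far as these compounds go, whether an aryl ring carrying an amine or a carboxylic acid on the sulfonyl sulfur would read differently remains open.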